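Adding Chloro to Compound 2: Expected Effect on Potency

The source may hold more compounds than are shown below. What is called first, only, known or untested is meant among the compounds shown, and "the series" means these compounds.

Measured compounds:
Compound 1, `Clc1cccc(-n2ccnc2)c1`, gives 41000 nM in an assay on cells for inhibition of Indoleamine 2,3-dioxygenase 1 (Homo sapiens), read by HPLC, with a stated time of 20 min; a higher number here means a weaker inhibitor, a lower number a stronger inhibitor.
Compound 2, `Oc1ccccc1-n1ccnc1`, gives 16000 nM in this assay.

Of the two measured compounds, compound 2 has the lower number in this assay, and its gap to compound 1 lies beyond the usual scatter of repeated measurements. Compound 3, `Oc1ccc(Cl)cc1-n1ccnc1`, has not yet been measured. It differs from compound 2 in a single place: chloro in place of hydrogen on an aromatic carbon. Among the measured compounds shown here, no measured pair shows what such an added chloro does on this core, so the direction and size of the step can only be guessed from the two numbers at hand, which suggest that changes on this ring do matter. The expectation is that compound 3 gives a moderately lower number than compound 2, a step of a 5.3-fold lower number from compound 2 to compound 3 (0.73 log units; beyond the scatter), because compound 2 already gives 16000 nM. Compound 3 is therefore estimated at 3000 nM, with a plausible range from 800 nM to 15000 nM.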

Compound 3, half-maximal inhibitory concentration: 2100 nM
Estimate against measurement, compound 3: 1.4-fold (0.15 log units) above, within the range that was stated.
By their numbers in this assay, from the lowest: compound 3; then compound 2; then compound 1.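

In this assay a chloro para to a hydroxy group and meta to a group of 5 heavy atoms brings a 7.6-fold lower number from compound 2 to compound 3 (0.88 log units; beyond the scatter) and so gives this core its first direct reading of what that single change does. The added hydroxy group brings a 20-fold lower number from compound 1 to compound 3 (1.29 log units; beyond the scatter) and shows that, with chloro already on the ring, this change also goes with a lower number. Nothing measured here explains either step.

From the compounds shown here alone, it remains open whether a chloro on another carbon of this ring would give a similar step. Going by these compounds, it is also open whether bromo, methyl or methoxy in the same place, or an amine in place of the hydroxy group, would keep the number this low.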